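The compounds below may be only part of what the source reports. "The series", "measured", "known", "first", "only" and "open" are said of these compounds alone.

Measured in a functional assay on A2780 cells (Homo sapiens) for inhibition, read by sulforhodamine B assay; a lower number here means a stronger inhibitor of growth, a higher number a weaker inhibitor of growth:
- Compound 1 `CN(C)c1ccc(-c2ccc(-c3ccc(-c4nc5c(O)cccc5[nH]4)cc3)cc2)cc1`: 3010 nM
- Compound 2 `Oc1cccc2[nH]c(-c3ccc(-c4ccc(-c5cccc(Cl)c5)cc4)cc3)nc12`: 2800 nM

Compound 2 stands level with compound 1, within the scatter. Compound 3 `COc1ccc(-c2ccc(-c3ccc(-c4nc5c(O)cccc5[nH]4)cc3)cc2)cc1OC` has 3,4-dimethoxyphenyl in place of 3-chlorophenyl on an aromatic carbon. Within the data shown here, one measured step bears on this change, an exchange of the terminal aromatic group: a 1.1-fold lower number from compound 1 to compound 2 (0.03 log units; within the scatter). That single step is small, so nothing beyond the scatter is expected in this assay, though one step is thin evidence. The expected change is a 1.1-fold higher number from compound 2 to compound 3 (0.03 log units; within the scatter). Compound 3 is estimated at 3000 nM, with an expected range of 1200 nM to 7000 nM.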

Compound 3, concentration for 50% growth inhibition: 2710 nM
Estimate against measurement, compound 3: 1.1-fold (0.04 log units) above, within the range that was stated.
By their numbers in this assay, from the lowest: compounds 3, 2 and 1 (each within the scatter of the next).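

In this assay, swapping in 3,4-dimethoxyphenyl leaves the number essentially unchanged, with a 1.0-fold lower number from compound 2 to compound 3 (0.01 log units; within the scatter) and a 1.1-fold lower number from compound 1 to compound 3 (0.05 log units; within the scatter). This position has now held three different substituted phenyl groups that all read level, even though 3,4-dimethoxyphenyl brings hydrogen-bond acceptors that 3-chlorophenyl lacks. Nothing available here accounts for why these groups read alike. As far as these compounds go, all three groups are aromatic rings, so it remains open how this position would respond to something else, such as a carboxylic acid or a longer alkyl chain.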